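A few compounds are considered here, and "the series" means these few. Any claim that something is new, unique, unknown or untested is made for them only; others in the source may bear on it.

Compound 1 `CCCc1nc(-c2ccccc2)c(CNCCCN2CCN(c3ccccc3Cl)CC2)o1`, compound 2 `CCCc1nc(-c2ccccc2)c(CNCCCN2CCN(c3ccccc3)CC2)o1` and compound 3 `CCCc1nc(-c2ccccc2)c(CNCCN2CCN(c3ccccc3)CC2)o1` were each tested in an assay on HEK293 cells for inhibition of Voltage-dependent T-type calcium channel subunit alpha-1G (Homo sapiens), read by fluorescence, tested at 10 uM; on this read-out lower numbers stand for less inhibition and higher numbers for more inhibition at the one concentration tested (going by the name of the read-out). In this assay compound 1 gives 64.7%, compound 2 gives 43.7%, and compound 3 gives 54.3%. Compound 1 and compound 2 differ in one place: chloro in place of hydrogen on an aromatic carbon. This change produced a number 21 percentage points higher from compound 2 to compound 1 (beyond the scatter). Compound 3 and compound 2 differ by more than one place, and the difference between the two cores is not broken down here.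

Compound 4 `CCCc1nc(-c2ccccc2)c(CNCCN2CCN(c3cccc(Cl)c3)CC2)o1` has not yet been measured in this assay. It differs from compound 3 as follows: chloro in place of hydrogen on an aromatic carbon. The change is the same kind of change as that from compound 2 to compound 1, though not the same, since in compound 1 the chloro sits ortho to a large group, while in compound 4 it sits meta to a large group. Resting on the step seen from compound 2 to compound 1, the step from compound 3 to compound 4 is expected to be a number 11.7 percentage points higher from compound 3 to compound 4 (beyond the scatter), somewhat smaller than the earlier one given the different place. Compound 4 is accordingly estimated at 66%, with a likely range from 50% to 80%.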

Compound 4, a percentage reported as inhibition, at one concentration (the size of the read-out at that concentration, not a potency): 51.2%
For compound 4 the middle estimate is 14.8 percentage points above the measured one; measured number inside the range.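

In this assay, chloro in place of hydrogen on an aromatic carbon did not carry over from one core to the other: the same change on two cores in this assay, a number 21 percentage points higher (beyond the scatter) from compound 2 to compound 1 and a number 3.1 percentage points lower (within the scatter) from compound 3 to compound 4, 24.1 percentage points apart, beyond the scatter of two such steps. Going by these compounds alone, the second step reads a number 3.1 percentage points lower from compound 3 to compound 4 (within the scatter), so the gain seen on reaching compound 1 has no counterpart on this core. This does not show whether the core or the place of the chloro accounts for the gap: the chloro of compound 4 sits meta to a large group and that of compound 1 does not, the two cores differ as well, and no pair shown separates these differences.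

The compounds shown leave open whether chloro at one and the same place would behave alike on both cores. They also leave open how other groups on that ring, such as fluoro, methoxy or trifluoromethyl, would fare on either core, so the result stands for chloro on these four compounds only.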